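This account rests on a few compounds, and the source may have more. Where it says the series, first, only, none or still open, it means among the compounds named here.

Working notes on the sulfonyl series.

Compound 1 `COc1ccc(S(=O)(=O)c2cc3cnc(Nc4ccc5[nH]ccc5c4)nc3n(C)c2=O)cc1` is the reference point. In a functional assay on DU-145 cells (Homo sapiens) for inhibition, read by trypan blue exclusion, with a stated time of 72 h (a lower number here means a stronger inhibitor, a higher number a weaker inhibitor), compound 1 gives 500 nM, the lowest of the three numbers in hand. Compound 2 `COc1ccc(S(=O)(=O)c2cc3cnc(Nc4cccc5[nH]ccc45)nc3n(C)c2=O)cc1` gives 5000 nM, and the step of a 10-fold higher number from compound 1 to compound 2 (1.00 log units; beyond the scatter) shows what moving the attachment of the indole does in this series. Compound 3 `Cc1cc2cc(Nc3ncc4cc(S(=O)(=O)c5ccc(F)cc5F)c(=O)n(C)c4n3)ccc2[nH]1` gives 750 nM; compound 1 and compound 3 lie within the scatter of each other, so nothing is read between them. Among the compounds with values here, compound 3 differs from compound 1 at both the sulfonyl aryl group and the indole, and no single step links the two, so only the two values themselves are taken.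

Compound 4 `Cn1c(=O)c(S(=O)(=O)c2ccc(N)cc2F)cc2cnc(Nc3ccc4[nH]ccc4c3)nc21` keeps the indole and the core of compound 1 and changes only the aryl group on the sulfonyl sulfur: 4-amino-2-fluorophenyl in place of 4-methoxyphenyl on a sulfonyl sulfur. Within the data shown here, no measured step in this set changes the sulfonyl aryl group alone. The nearest indication is that compound 3, which carries a different fluorinated aryl on the sulfonyl sulfur, sits within the scatter of compound 1 in this assay. On that basis the expectation is a step of no change at the digits printed from compound 1 to compound 4 (within the scatter), not beyond the scatter. Compound 4 is therefore estimated at 500 nM, with a range from 170 nM to 1500 nM.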

Compound 4, half-maximal inhibitory concentration: 8000 nM
Compound 4: middle estimate off by 16-fold (1.20 log units), on the low side; measured number above the stated range.
By their numbers in this assay, from the lowest: compounds 1 and 3 (each within the scatter of the next); then compounds 2 and 4 (each within the scatter of the next).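

In this assay the aryl group on the sulfonyl sulfur proves to be a position that moves the number by itself, with the indole and the core of compound 1 unchanged: 4-amino-2-fluorophenyl in place of 4-methoxyphenyl gives a 16-fold higher number from compound 1 to compound 4 (1.20 log units; beyond the scatter) as the first single-place step read at this position. Within the data shown here, until now the only such step was at the indole attachment, a 10-fold higher number from compound 1 to compound 2 (1.00 log units; beyond the scatter) being the change there, so the sulfonyl aryl group is now a second place where a single change carries the number beyond the scatter. The entering group differs from the leaving one in more than one feature, since it brings an amino group and a fluorine and loses the methoxy group, and nothing on hand bears on why the number rises.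

The compounds shown do not separate the amino group from the fluorine, so a phenyl carrying only one of the two, or a plain phenyl on the sulfonyl sulfur, remains the open comparison. Also open, on these data alone, is whether other groups on that ring, such as a nitrile or a carboxylic acid, behave like the amine or like the methoxy group.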